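This account rests on a few compounds, and the source may have more. Where it says the series, first, only, none or still open, it means among the compounds named here.

Working notes on the series in a functional assay on MCF7 cells (Homo sapiens) for cytotoxicity, read by MTT assay, with a stated time of 96 h; a lower number here means a stronger inhibitor, a higher number a weaker inhibitor: compound 1 (`COc1cc(C(=O)c2cn(-c3ccccc3)cc2-c2ccc(N)cc2)cc(OC)c1OC`) gives 9 nM, compound 2 (`COc1cc(C(=O)c2cn(-c3ccccc3)cc2-c2ccccc2Cl)cc(OC)c1OC`) gives 76 nM, and compound 3 (`COc1cc(C(=O)c2cn(-c3ccccc3)cc2-c2ccccc2[N+](=O)[O-])cc(OC)c1OC`) gives 49 nM. Compound 3 stands level with compound 2, and compound 1 is the strongest inhibitor of the three.

Compound 4 (`COc1ccccc1-c1cn(-c2ccccc2)cc1C(=O)c1cc(OC)c(OC)c(OC)c1`) has methoxy in place of nitro on an aromatic carbon, ortho to a large group: methoxy in place of nitro on an aromatic carbon.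

The closest evidence is the earlier exchange at that same place, nitro in place of chloro, which gave a 1.6-fold lower number from compound 2 to compound 3 (0.19 log units; within the scatter). The two larger steps, an 8.4-fold higher number from compound 1 to compound 2 (0.93 log units; beyond the scatter) and a 5.4-fold higher number from compound 1 to compound 3 (0.74 log units; beyond the scatter), exchange a whole substituted phenyl group and bear on this change less directly. Going by the values given here, no measured step covers methoxy itself, so the expectation is uncertain. No step beyond the scatter is expected in this assay.

The estimate amounts to a 1.2-fold lower number from compound 3 to compound 4 (0.09 log units; within the scatter), which is expected to lie within the scatter. Compound 4 is estimated at 40 nM, with an expected range of 12 nM to 130 nM.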

Compound 4, half-maximal inhibitory concentration: 190 nM
Beside the measured number, compound 4's estimate is 4.8-fold (0.68 log units) below it; measured number above the stated range.
By their numbers in this assay, from the lowest: compound 1; then compounds 3 and 2 (each within the scatter of the next); then compound 4.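

In this assay, the earlier exchange at this place, between chloro and nitro, stayed within the scatter, whereas methoxy moves the number beyond it: a 3.9-fold higher number from compound 3 to compound 4 (0.59 log units; beyond the scatter) and a 2.5-fold higher number from compound 2 to compound 4 (0.40 log units; beyond the scatter). This position therefore does not accept every group alike, and compound 4 is the weakest inhibitor of the four; the exchange of 4-aminophenyl for 2-methoxyphenyl gives a 21-fold higher number from compound 1 to compound 4 (1.32 log units; beyond the scatter). No measurement shown accounts for methoxy standing apart from chloro and nitro.

As far as these compounds go, whether this loss belongs to methoxy alone or extends to other oxygen-linked groups, such as hydroxyl or ethoxy, remains open at this place. An amine at this same place would also be needed to separate the identity of the group from its place on the phenyl ring, as these two differ together between compound 1 and the other compounds.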